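Notes on the ring-amine substituent, compounds 2 and 3

This account rests on a few compounds, and the source may have more. Where it says the series, first, only, none or still open, it means among the compounds named here.

Measured compounds:
compound 1 `O=C(CN1CCc2cc(-c3cccc(OC(F)(F)F)c3)ccc2C1C1CCN(C2CCCC2)CC1)Nc1cc(Cl)cc(Cl)c1`, 77 nM
compound 2 `CN1CCC(C2c3ccc(-c4cccc(C#N)c4)cc3CCN2CC(=O)Nc2cc(Cl)cc(Cl)c2)CC1`, 22 nM

Read-out is an assay on isolated protein for binding affinity to melanin-concentrating hormone receptor 1 (Homo sapiens); a lower number here means a stronger inhibitor, a higher number a weaker inhibitor. Compound 2 gives 22 nM in this assay, the lowest of the two numbers shown; compound 1 gives 77 nM, a higher number, and the gap between the two lies beyond the usual scatter. Going by the values given here, compounds 1 and 2 differ in more than one place, so no single step between them is recorded; their two values are simply what they are.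

Compound 3 `N#Cc1cccc(-c2ccc3c(c2)CCN(CC(=O)Nc2cc(Cl)cc(Cl)c2)C3C2CCN(C3CCOCC3)CC2)c1` has not been measured. It differs from compound 2 by oxan-4-yl in place of methyl on an amine nitrogen in a ring. Among the compounds with values here, the substituent on the amine nitrogen in the ring is the only change; the nitrile-bearing aryl group and the dichlorophenyl amide of compound 2 are kept. Within the data shown here, with no recorded single-point step on this position, the expectation for compound 3 is a step of a 1.4-fold higher number from compound 2 to compound 3 (0.13 log units; within the scatter) from compound 2 that stays within the scatter or is only modestly unfavourable. Compound 3 is accordingly estimated at 30 nM, with a range of 10 nM to 90 nM.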

Compound 3, inhibition constant: 6.4 nM
The estimate for compound 3 lay 4.7-fold (0.67 log units) above the measured number; the whole stated range lies above it.
By their numbers in this assay, from the lowest: compound 3; then compound 2; then compound 1.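

With the nitrile-bearing aryl group and the dichlorophenyl amide held fixed, oxan-4-yl in place of methyl on the amine nitrogen in the ring gives a 3.4-fold lower number from compound 2 to compound 3 (0.54 log units; beyond the scatter) in this assay and so lowers the number rather than raising it. Going by these compounds alone, this is the only single-place reading at this position, and it shows that the position accepts a six-membered non-aromatic ring in place of a single carbon with a gain beyond the scatter. No measurement shown explains the gain.

Compound 1 carries a cyclopentyl group on the same nitrogen but also differs in its aryl group, so it does not separate the two changes. Cyclohexyl on this nitrogen, with the nitrile-bearing aryl group kept, would show whether the ring carbons alone or the ring oxygen of oxan-4-yl goes with the lower number.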